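Bromo for Chloro: A Step Expected Within the Scatter

This account rests on a few compounds, and the source may have more. Where it says the series, first, only, none or still open, it means among the compounds named here.

In an assay for inhibition of cathepsin H (Capra hircus), using Lineweaver-Burk analysis (on this read-out higher numbers stand for weaker inhibition and lower numbers for stronger inhibition), compound 2 `Clc1ccc(C2CC(c3ccccc3)=NN2c2ccccc2)cc1` gives 1170 nM. Compound 1 `COc1ccc(/C=C/C(=N\Nc2ccccc2)c2ccccc2)cc1` gives 1700 nM in this assay, a number that lies within the usual scatter of that of compound 2, so the two cannot be told apart. Compound 3 `Brc1ccc(C2CC(c3ccccc3)=NN2c2ccccc2)cc1` differs from compound 2 by bromo in place of chloro on an aromatic carbon. Among the compounds with values here, no measured pair shows this change, so there is no step to lean on. Since the change exchanges one halogen for another of the same count, the step of a 1.1-fold lower number from compound 2 to compound 3 (0.03 log units; within the scatter) is expected to stay within the scatter. Compound 3 is therefore estimated at 1100 nM, with a range from 500 nM to 2500 nM.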

Compound 3, inhibition constant: 3160 nM
Compound 3: middle estimate off by 2.9-fold (0.46 log units), on the low side, and the stated range ends below it.
By their numbers in this assay, from the lowest: compounds 2, 1 and 3 (each within the scatter of the next, the first and the last beyond it).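

In this assay bromo in place of chloro on the 4-chlorophenyl group gives a 2.7-fold higher number from compound 2 to compound 3 (0.43 log units; beyond the scatter) and so moves inhibition to the weaker side, beyond the scatter. The earlier compounds shown here could not be told apart, whereas this pair shows that this position responds to the exchange of one halogen for another. Nothing at hand explains the step.

As far as these compounds go, it remains open how this position would respond to fluoro, methoxy or an amine in the same place. A single pair also leaves open whether the step would recur on another core.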